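This account rests on a few compounds, and the source may have more. Where it says the series, first, only, none or still open, it means among the compounds named here.

In a functional assay on A549 cells (Homo sapiens) for antiproliferative activity, read by MTT assay, with a stated time of 72 h (a lower number here means a stronger inhibitor, a higher number a weaker inhibitor), compound 1 `CCOC1=C(C(=O)c2ccccc2)C(c2ccc(Br)cc2)N(CCCn2ccnc2)C1=O` gives 35300 nM, a weak result. Compound 2 `NC1=C(C(=O)c2ccccc2)C(c2ccc(Br)cc2)N(CCCn2ccnc2)C1=O` is reported in this assay as "not active" (no number reported), so no number places it on the scale; it stands as the inactive member of the pair. Compound 3 `O=C(C1=C(Nc2ccccc2)C(=O)N(CCCn2ccnc2)C1c1ccc(Br)cc1)c1ccccc1` differs from compound 2 by phenyl in place of hydrogen on an amine nitrogen, amino to anilino. Within the data shown here, with no measured step between compound 2 and compound 3, the direction of change cannot be read from the data, and a weak value near that of compound 1 is the plainest expectation. Compound 3 is therefore expected to give about 40000 nM in this assay, between 10000 nM and 150000 nM, with a real chance that only a limit is reported.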

Compound 3, half-maximal inhibitory concentration: 24100 nM
For compound 3 the middle estimate is 1.7-fold (0.22 log units) above the measured one; the measured number falls inside the stated range.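

On the double-bonded ring carbon, anilino in place of ethoxy gives a 1.5-fold lower number from compound 1 to compound 3 (0.17 log units; within the scatter) in this assay, so these two groups are not told apart here. Compound 2, with amino at this place, is reported as not active, whereas compound 3, with phenyl on that amine nitrogen, gives 24100 nM, although no step can be read for this pair. No measured evidence bears on this result. Still open, on these data alone, is whether a benzylamino or morpholino group on this ring carbon would give a value clearly apart from these, and what a methoxy or chlorine on the phenyl of the anilino would do.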